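The source may report more compounds than this note shows. Statements on the series, on what has been measured and on what is new or still open speak of the compounds shown alone.

Measured in a functional assay on HCT-116 cells (Homo sapiens) for cytotoxicity, read by MTT assay, with a stated time of 72 h; on this read-out lower numbers stand for stronger inhibition and higher numbers for weaker inhibition:
- compound 1 `O=C1c2c[n+]([O-])c3ccccc3c2C(=O)c2c1c1ccccc1n2CCCCn1ccnc1` gives 240 nM
- compound 2 `CC1(C)OCC(Cn2cc(Cn3c4c(c5ccccc53)C(=O)c3c[n+]([O-])c5ccccc5c3C4=O)nn2)O1` gives 70 nM

Compound 1 has the higher number of the two, and the gap to compound 2 lies beyond the scatter. Compound 3 `O=C1c2c[n+]([O-])c3ccccc3c2C(=O)c2c1c1ccccc1n2CCCCN1CCCCC1` is not yet measured. Relative to compound 1, it carries piperidin-1-yl in place of 1H-imidazol-1-yl on a saturated chain carbon, four bonds along the chain from an aromatic nitrogen. Within the data shown here, no measured pair isolates this change, so the expectation is only loose. The estimated change is a 1.3-fold lower number from compound 1 to compound 3 (0.12 log units; within the scatter), with no step beyond the scatter expected. Compound 3 is expected at 180 nM (estimated range 60 nM to 550 nM).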

Compound 3, half-maximal inhibitory concentration: 200 nM
For compound 3 the middle estimate is 1.1-fold (0.05 log units) below the measured one; low and high end bracket the measured number.
By their numbers in this assay, from the lowest: compound 2; then compounds 3 and 1 (each within the scatter of the next).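

In this assay, piperidin-1-yl in place of 1H-imidazol-1-yl gives a 1.2-fold lower number from compound 1 to compound 3 (0.08 log units; within the scatter) and so, at this position on the saturated chain, a six-membered non-aromatic ring with 1 hetero atom reads the same as a five-membered aromatic ring with 2 hetero atoms. The read-out therefore does not separate these two ring types here. No measured evidence bears on this result.

As far as these compounds go, how morpholin-4-yl or a primary amine would read on the same chain carbon remains open. So does the effect of a longer chain carrying either ring.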